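The compounds below may be only part of what the source reports. "The series", "measured", "known", "first", "only" and "open" are said of these compounds alone.

Measured so far:
- compound 1, `Cc1nc(/N=N/c2ccc(C(=O)O)cc2)c(COP(=O)(O)O)c(C=O)c1O`: 100000 nM
- compound 2, `Cc1nc(/N=N/c2cc(S(=O)(=O)O)ccc2S(=O)(=O)O)c(COP(=O)(O)O)c(COP(=O)(O)O)c1O`: 100000 nM

Compound 1 is `Cc1nc(/N=N/c2ccc(C(=O)O)cc2)c(COP(=O)(O)O)c(C=O)c1O`. In a functional assay on cell membranes for inhibition of P2Y purinoceptor 1 (Meleagris gallopavo) (a lower number here means a stronger inhibitor, a higher number a weaker inhibitor), compound 1 gives 100000 nM. Compound 2, `Cc1nc(/N=N/c2cc(S(=O)(=O)O)ccc2S(=O)(=O)O)c(COP(=O)(O)O)c(COP(=O)(O)O)c1O`, carries two sulfo groups on its azo-linked benzene ring and a second phosphate on the shared core. In this assay compound 2 gives 100000 nM. On the numbers, compound 2 stands level with compound 1: the two values show no difference beyond the scatter, so neither can be called the stronger inhibitor.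

Compound 3 is `Cc1nc(/N=N/c2cc(S(=O)(=O)O)ccc2Cl)c(COP(=O)(O)O)c(COP(=O)(O)O)c1O`. It differs from compound 2 in one place: chloro in place of sulfo on an aromatic carbon. The change sits on an aromatic carbon of a six-membered aromatic ring of carbon only, ortho to a large group and para to a sulfo group.

Going by the values given here, no step between measured compounds has been worked out here, so the size of this step can only be expected, not read off. Since compound 2 gives 100000 nM and compound 1 likewise gives 100000 nM, the two measured compounds show no movement at all, and compound 3 is expected to stay in the same range, with a step from compound 2 of no change at the digits printed from compound 2 to compound 3 (within the scatter), none beyond the scatter. For compound 3 the estimate in this assay is 100000 nM, within 25000 nM to 100000 nM.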

Compound 3, half-maximal inhibitory concentration: 100000 nM
Beside the measured number, compound 3's estimate shows no gap at the digits printed; low and high end bracket the measured number.
By their numbers in this assay, from the lowest: compounds 1, 2 and 3 (each within the scatter of the next).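

Going by these compounds alone, the step of no change at the digits printed from compound 2 to compound 3 (within the scatter) in this assay is the first single-place comparison here, and it concerns the aromatic carbon ortho to a large group and para to a sulfo group. At this position, in this assay, chloro, with 1 heavy atom and no hydrogen-bond donors or acceptors, cannot be told apart from sulfo, with 4 heavy atoms, 1 hydrogen-bond donor and 2 hydrogen-bond acceptors, so this difference between the two groups leaves no mark on the read-out. No measurement offered here accounts for this result, and compound 3, at 100000 nM, gives no sign of which parts of the structure bear on inhibition.

The compounds shown leave open whether any other group on this carbon, such as an amine or a methoxy group, would give a value that differs from those of compound 2 and compound 3. They also leave open what a carboxylic acid or a chloro in place of the remaining sulfo group would do on the same ring.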